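Acetyl on the aromatic amino nitrogen of compound 1

A few compounds are considered here, and "the series" means these few. Any claim that something is new, unique, unknown or untested is made for them only; others in the source may bear on it.

Measured so far in a functional assay on the whole organism with Mus musculus as the target; on this read-out lower numbers stand for an effect already at smaller amounts and higher numbers for an effect only at larger amounts of compound
compound 1 `Cc1cc(C(=O)Nc2c(C)cccc2C)ccc1N` gives 84 mg/kg
compound 2 `Cc1cc(C(=O)Nc2c(C)cccc2C)cc(C)c1N` gives 64 mg/kg

Compound 1 and compound 2 lie within the scatter of each other, so compound 1 holds no distinct place on these numbers. Going by the values given here, the only measured step (a 1.3-fold lower number from compound 1 to compound 2 (0.12 log units; within the scatter)) is methyl in place of hydrogen on an aromatic carbon. Compound 3 (`CC(=O)Nc1ccc(C(=O)Nc2c(C)cccc2C)cc1C`) differs from compound 1 by acetyl in place of hydrogen on a nitrogen on an aromatic ring, amino to acetamido (acetyl in place of hydrogen on a nitrogen on an aromatic ring). Among the compounds with values here, the methyl step concerns another place and another group, and no measured step touches this nitrogen, so it sets no size for the change. A moderate move to a higher number in this assay is expected, held loosely. As a step, the estimate is a 1.5-fold higher number from compound 1 to compound 3 (0.19 log units; within the scatter) and remains a rough expectation. For compound 3 the estimated value is 130 mg/kg with an expected range from 50 mg/kg to 340 mg/kg in this read-out.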

Compound 3, dose for half-maximal effect: 56 mg/kg
Compound 3: middle estimate off by 2.3-fold (0.37 log units), on the high side; low and high end bracket the measured number.
By their numbers in this assay, from the lowest: compounds 3, 2 and 1 (each within the scatter of the next).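

Acetyl on the aromatic amino nitrogen was the first change at this nitrogen, and in this assay it gives a 1.5-fold lower number from compound 1 to compound 3 (0.18 log units; within the scatter). On these numbers, amino to acetamido at this position therefore produces no step beyond the scatter, so the free amino group is not needed to keep the read-out in this range. No evidence on hand bears on the reason for this result.

On these data alone, whether a longer acyl chain such as propionyl, a methanesulfonyl group or a dimethylamino group on this nitrogen would stay within the scatter of compound 1 remains open. Also open is how acetyl on this nitrogen reads together with the extra methyl of compound 2, since the compounds shown carry each change only separately.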